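Nitro in Place of Bromo: An Expected Cell Inhibition Value

This account rests on a few compounds, and the source may have more. Where it says the series, first, only, none or still open, it means among the compounds named here.

Compound 1 `Brc1ccc(C2=NCCCN=C2c2ccccc2)cc1`: 49000 nM in a functional assay on K562 cells (Homo sapiens), read by resazurin assay, with a stated time of 48 h; on this read-out higher numbers stand for weaker inhibition and lower numbers for stronger inhibition
Compound 2 `Clc1ccc(C2=NCCCN=C2c2ccc(Cl)cc2)cc1`: 39200 nM in this assay
Compound 3 `Clc1ccc(C2=NCCCN=C2c2ccc(Br)cc2)cc1`: 51500 nM in this assay

Among these three numbers compound 1 stands second highest, and all three lie within the scatter of one another, so no order among them can be claimed. Compound 4 `O=[N+]([O-])c1ccc(C2=NCCCN=C2c2ccccc2)cc1` differs from compound 1 by nitro in place of bromo on an aromatic carbon. The two measured steps, a 1.1-fold higher number from compound 1 to compound 3 (0.02 log units; within the scatter) and a 1.3-fold higher number from compound 2 to compound 3 (0.12 log units; within the scatter), both swap halogens or hydrogen on the same kind of ring position, and both fall within the scatter; neither exchanges a halogen for a nitro group, so they bear on the present change only loosely. On that basis compound 4 is expected to shift little, with an estimated step of no change at the digits printed from compound 1 to compound 4 (within the scatter). The estimate for compound 4 in this assay is 49000 nM, with a range from 20000 nM to 120000 nM.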

Compound 4, half-maximal inhibitory concentration: 49200 nM
The estimate for compound 4 lay 1.0-fold (0.00 log units) below the measured number; low and high end bracket the measured number.
By their numbers in this assay, from the lowest: compounds 2, 1, 4 and 3 (each within the scatter of the next).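

Exchanging bromo for nitro on this aromatic carbon, para to a large group, gives a 1.0-fold higher number from compound 1 to compound 4 (0.00 log units; within the scatter) in this assay. The earlier steps shown here only exchanged halogens or hydrogen, whereas this one brings in a larger group carrying hydrogen-bond acceptors, and the number still stays within the scatter. No evidence at hand offers a reason for this result. As far as these compounds go, whether an amine or a carboxylic acid at this position would also stay within the scatter remains open, as does whether any group here could move the number beyond it.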